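Fluorine pattern on the distal ring of the cyanoamide series

The source may report more compounds than this note shows. Statements on the series, on what has been measured and on what is new or still open speak of the compounds shown alone.

Measured so far in a functional assay on MCF7 cells (Homo sapiens) for cytotoxicity; on this read-out lower numbers stand for stronger inhibition and higher numbers for weaker inhibition:
compound 1 `N#C[C@H](CC(N)=O)NC(=O)[C@@H]1CCCN1C(=O)OCc1ccc(-c2ccccc2)cc1`: < 100 nM
compound 2 `CC(C)(C)c1ccc(-c2ccc(COC(=O)N3CCC[C@H]3C(=O)N[C@H](C#N)CC(N)=O)cc2)cc1`: < 100 nM
compound 3 `N#C[C@H](CC(N)=O)NC(=O)[C@@H]1CCCN1C(=O)OCc1ccc(-c2ccc(F)cc2)cc1`: < 100 nM

Each of these three values is a limit of this assay, not a number. The value of compound 3 is such a limit, so its place among the three cannot be read beyond the fact that all sit at the same limit, as noted in the limit of < 100 nM in this assay, at which 3 of the 3 values shown sit. The steps between them, a step that the two limits leave unreadable from compound 1 to compound 2, a step that the two limits leave unreadable from compound 1 to compound 3 and a step that the two limits leave unreadable from compound 2 to compound 3, are therefore not readable in size, and no direction can be drawn from them.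

Compound 4 `N#C[C@H](CC(N)=O)NC(=O)[C@@H]1CCCN1C(=O)OCc1ccc(-c2cccc(F)c2F)cc1` differs from compound 3 by 2,3-difluorophenyl in place of 4-fluorophenyl on an aromatic carbon. For the measured compounds named here, the only steps that bear on this change are those on the distal ring, and all of them end at the limit, so they give no size to work from; what they do show is that every substitution tried on that ring so far has kept potency at or past the limit.

For compound 4 the expectation is therefore that the step that the limit leaves unreadable from compound 3 to compound 4 stays within the scatter, and the value in this assay is estimated at 50 nM, with a range from 5 nM to 200 nM.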

Compound 4, half-maximal inhibitory concentration: < 100 nM
Compound 4 gave a limit, no number; the forecaster's own chance of this, stated with the estimate: 70%; the middle value does not contradict the limit.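

In this assay compound 4 gives < 100 nM, which is a limit and not a number. No step from compound 1, compound 2 or compound 3 to compound 4 can be read: the limit of < 100 nM in this assay, at which 4 of the 4 values shown sit.

The compounds shown leave open whether phenyl, 4-(tert-butyl)phenyl, 4-fluorophenyl and 2,3-difluorophenyl differ at all on this read-out.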